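A few compounds are considered here, and "the series" means these few. Any claim that something is new, unique, unknown or untested is made for them only; others in the source may bear on it.

Going by the values given here, in a functional assay on A549 cells (Homo sapiens) for antiproliferative activity, read by MTT assay, with a stated time of 72 h (on this read-out higher numbers stand for weaker inhibition and lower numbers for stronger inhibition), compound 2 `O=C1O[C@H]([C@@H](O)Cn2cc(CNS(=O)(=O)c3ccc(F)cc3)nn2)C(OCc2ccccc2)=C1OCc1ccccc1` gives 22500 nM, and that is the only number in the set. Compound 1 `COc1ccc(-c2cn(C/C=C3\OC(=O)C(OCc4ccccc4)=C3OCc3ccccc3)nn2)cc1` returns only a limit in this assay, > 100000 nM; this is the limit of > 100000 nM in this assay, at which 1 of the 2 values shown sits. Compound 3 `Cc1ccc(S(=O)(=O)NCc2cn(C[C@H](O)[C@H]3OC(=O)C(OCc4ccccc4)=C3OCc3ccccc3)nn2)cc1` differs from compound 2 by methyl in place of fluoro on an aromatic carbon. Among the compounds with values here, no pair of measured compounds shows a step of this kind, so the step of a 1.1-fold lower number from compound 2 to compound 3 (0.05 log units; within the scatter) is expected to stay within the usual scatter, with no clear direction up or down. Compound 3 is accordingly estimated at 20000 nM, with a range from 8000 nM to 60000 nM.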

Compound 3, half-maximal inhibitory concentration: 16800 nM
For compound 3 the middle estimate is 1.2-fold (0.08 log units) above the measured one, within the range that was stated.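

At this place on the aromatic ring, para to a large group, methyl in place of fluoro gives in this assay a 1.3-fold lower number from compound 2 to compound 3 (0.13 log units; within the scatter). This first measured step at the position shows that the read-out does not separate 4-fluorophenyl from 4-methylphenyl here. Nothing measured in the set bears on this step beyond the values themselves. Still open, from the compounds shown here alone, is whether an amine, a carboxylic acid or a longer chain at this position would give a step beyond the scatter.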